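This account rests on a few compounds, and the source may have more. Where it says the series, first, only, none or still open, it means among the compounds named here.

Of the compounds shown here, three with a shared core have been tested in an assay on isolated protein for agonist activity at prostaglandin E2 receptor EP2 subtype (Homo sapiens); on this read-out lower numbers stand for an effect already at smaller amounts and higher numbers for an effect only at larger amounts of compound. Compound 1 `CCCCC1([C@H](O)/C=C/[C@H]2COC(=O)N2CCSc2nc(C(=O)O)cs2)CCC1` gives 2.9 nM. Compound 2 `CC(C)(C)CCC1([C@H](O)/C=C/[C@H]2COC(=O)N2CCSc2nc(C(=O)O)cs2)CCC1` gives 3700 nM, and compound 3 `O=C(O)c1csc(SCCN2C(=O)OC[C@@H]2/C=C/[C@@H](O)C2(CCc3ccccc3)CCC2)n1` gives 160 nM. Compound 3 thus stands in the middle of the three: the step of a 55-fold higher number from compound 1 to compound 3 (1.74 log units; beyond the scatter) separates it from compound 1, while the step of a 23-fold lower number from compound 2 to compound 3 (1.36 log units; beyond the scatter) separates it from compound 2. The step of a 1300-fold higher number from compound 1 to compound 2 (3.11 log units; beyond the scatter) shows how strongly this assay responds to changes at this place on the chain.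

Compound 4 `COCCCC1([C@H](O)/C=C/[C@H]2COC(=O)N2CCSc2nc(C(=O)O)cs2)CCC1` differs from compound 3 by methoxymethyl in place of phenyl on a saturated chain carbon, two bonds along the chain from a saturated ring carbon. Going by the values given here, no measured step covers this exact exchange, but the steps already seen show that a bulky group at this place gives a higher number than ethyl, and phenyl sits between them. The entering methoxymethyl leaves a chain of a length close to that of compound 1, so a lower number than for compound 3 is expected, though not necessarily all the way down to compound 1. Compound 4 is therefore estimated at 15 nM, with a range from 3 nM to 80 nM, which means an expected step of an 11-fold lower number from compound 3 to compound 4 (1.03 log units; beyond the scatter).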

Compound 4, half-maximal effective concentration: 18 nM
Compound 4: middle estimate off by 1.2-fold (0.08 log units), on the low side, and the stated range covers the measured number.
By their numbers in this assay, from the lowest: compound 1; then compound 4; then compound 3; then compound 2.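

Methoxymethyl in place of phenyl brings an 8.9-fold lower number from compound 3 to compound 4 (0.95 log units; beyond the scatter) and in place of tert-butyl brings a 210-fold lower number from compound 2 to compound 4 (2.31 log units; beyond the scatter) at this place on the chain, so among these three groups the one with an oxygen and no ring gives the lowest number. Even so, methoxy in place of methyl on a saturated chain carbon, three bonds along the chain from a saturated ring carbon, leaves a 6.2-fold higher number from compound 1 to compound 4 (0.79 log units; beyond the scatter) and does not match the all-carbon chain. No measurement shown here explains why these numbers differ.

The compounds shown leave open whether the oxygen itself or some other feature of the chain sets the number at this place. A hydroxyl, an amine or a fluorine at the same place, or a longer chain ending in methoxy, would help to separate these possibilities.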